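From butylamino to pyrrolidin-1-yl on a carbonyl carbon

The source may report more compounds than this note shows. Statements on the series, on what has been measured and on what is new or still open speak of the compounds shown alone.

- Compound 1 `CCCCc1oc2ccccc2c1C(=O)c1ccc(OCC(=O)N2CCCCC2)cc1` gives > 50000 nM (a limit)
- Compound 2 `CCCCc1oc2ccccc2c1C(=O)c1ccc(OCC(=O)Nc2cccc(OC)c2)cc1` gives > 50000 nM (a limit)
- Compound 3 `CCCCNC(=O)CCCOc1ccc(C(=O)c2c(CCCC)oc3ccccc23)cc1` gives 38100 nM (a number)

These values come from a functional assay on MDA-MB-231 cells (Homo sapiens) for antiproliferative activity, read by MTT assay, with a stated time of 24 h (on this read-out higher numbers stand for weaker inhibition and lower numbers for stronger inhibition), and compound 3 alone carries a number. Compound 1 and compound 2 stand at the limit of > 50000 nM in this assay, at which 2 of the 3 values shown sit (a limit and not a number).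

Compound 4 `CCCCc1oc2ccccc2c1C(=O)c1ccc(OCCCC(=O)N2CCCC2)cc1` has not yet been measured. It differs from compound 3 by one change: pyrrolidin-1-yl in place of butylamino on a carbonyl carbon. In words, pyrrolidin-1-yl stands in place of butylamino on a carbonyl carbon.

The nearest comparison is an at least 1.3-fold lower number from compound 1 to compound 3 (0.11 log units; that floor lies within the scatter), and that step also alters the chain. The second comparison is an at least 1.3-fold lower number from compound 2 to compound 3 (0.11 log units; that floor lies within the scatter), which alters the chain as well. The remaining step is a step that the two limits leave unreadable from compound 1 to compound 2. None of these isolates the change at hand, so no step beyond the scatter is expected in this assay. The expected change is a 1.2-fold higher number from compound 3 to compound 4 (0.07 log units; within the scatter). Compound 4 is estimated at 45000 nM, with an expected range from 20000 nM to 90000 nM.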

Compound 4, half-maximal inhibitory concentration: 48700 nM
Estimate against measurement, compound 4: 1.1-fold (0.03 log units) below, within the range that was stated.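

In this assay, among these compounds, a 1.3-fold higher number from compound 3 to compound 4 (0.11 log units; within the scatter) is the first step to isolate this carbonyl carbon, where the chain stays fixed. Butylamino, with one hydrogen-bond donor and no ring, gives way to pyrrolidin-1-yl, with no donor and a five-membered ring, and the reading stays within the scatter. The comparisons that also alter the chain add only floors, an at least 1.0-fold lower number from compound 2 to compound 4 (0.01 log units; that floor lies within the scatter) and an at least 1.0-fold lower number from compound 1 to compound 4 (0.01 log units; that floor lies within the scatter), which cannot be sized further: the limit of > 50000 nM in this assay, at which 2 of the 4 values shown sit.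

The compounds shown leave open whether any group on this carbonyl carbon can move the reading beyond the scatter, for example a morpholin-4-yl ring, a piperazin-1-yl ring or a carboxylic acid in place of the amide. They also leave open what a longer chain would do when the amide is held constant.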